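The compounds below may be only part of what the source reports. "The series", "measured", "known", "first", "only" and "open" are said of these compounds alone.

Compound 1, `Cc1ccc(Nc2cc(C)nc(SCc3nc4ccccc4[nH]3)n2)cc1`: in a functional assay on ECa-109 cells (Homo sapiens) for cytotoxicity, read by MTT assay, with a stated time of 72 h (a lower number here means a stronger inhibitor, a higher number a weaker inhibitor), compound 1 gives 57300 nM.
Compound 2, `Cc1cc(Nc2cccc(C(F)(F)F)c2)nc(SCc2nc3ccccc3[nH]2)n1`: in this assay compound 2 gives > 100000 nM, a limit of the assay rather than a number.
Compound 3, `Cc1cc(NCCO)nc(SCc2nc3ccccc3[nH]2)n1`: in this assay compound 3 gives > 100000 nM, likewise a limit.

Compound 3 thus stands at the limit of > 100000 nM in this assay, at which 2 of the 3 values shown sit, with no number of its own. Compound 4, `Cc1cc(N2CCCCC2)nc(SCc2nc3ccccc3[nH]2)n1`, differs from compound 3 in one place: piperidin-1-yl in place of (2-hydroxyethyl)amino on an aromatic carbon. Among the compounds with values here, the only measured step touching this position is an at least 1.7-fold higher number from compound 1 to compound 3 (0.24 log units; that floor lies within the scatter), which runs from a number into the limit and so gives no firm size. Within the data shown here, no measured compound carries a piperidin-1-yl group at this place. The working expectation is a step within the scatter, with a real chance that compound 4 again sits at the limit. Compound 4 is estimated at 90000 nM, with a range from 30000 nM to 300000 nM. The expected step is an at least 1.1-fold lower number from compound 3 to compound 4 (0.04 log units; that floor lies within the scatter).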

Compound 4, half-maximal inhibitory concentration: > 100000 nM
Compound 4: no number, only a limit; the forecaster's own chance of this, stated with the estimate: 60%; middle value at least 1.1-fold (0.04 log units) from the limit.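

In this assay compound 4 gives a limit rather than a number, so the step for piperidin-1-yl in place of (2-hydroxyethyl)amino cannot be read. Set against the only number in the series, the change reads as an at least 1.7-fold higher number from compound 1 to compound 4 (0.24 log units; that floor lies within the scatter), a floor with no firm size. A non-aromatic ring on this aromatic carbon thus ends at the same limit as the open chain: the limit of > 100000 nM in this assay, at which 3 of the 4 values shown sit.

Compound 2, compound 3 and compound 4 cannot be ranked against one another. From the compounds shown here alone, whether morpholin-4-yl, piperazin-1-yl or a 4-methoxyphenylamino group here would give a number remains open.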